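Chlorophenyl in Place of Methoxyphenyl: Compound 2 to Compound 4

This account rests on a few compounds, and the source may have more. Where it says the series, first, only, none or still open, it means among the compounds named here.

Compound 1 `CC1=CC[C@H](C(C)(C)N=C=S)CC1` — in a functional assay on MCF7 cells (Homo sapiens) for inhibition, read by sulforhodamine B assay, with a stated time of 48 h (a higher number here means a weaker inhibitor of growth, a lower number a stronger inhibitor of growth), compound 1 reaches only a limit of the assay, > 100000 nM.
Compound 2 `COc1ccc(/C=N/NC(=S)NC(C)(C)[C@H]2CC=C(C)CC2)cc1` — in this assay compound 2 gives 37700 nM.
Compound 3 `CC1=CC[C@H](C(C)(C)NC(=S)N/N=C/c2ccccc2Cl)CC1` — in this assay compound 3 gives 98300 nM.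

Compound 2 holds the lowest of the two numbers, with compound 3 nearest through a 2.6-fold higher number from compound 2 to compound 3 (0.42 log units; beyond the scatter). Compound 4 `CC1=CC[C@H](C(C)(C)NC(=S)N/N=C/c2cccc(Cl)c2)CC1` differs from compound 2 by 3-chlorophenyl in place of 4-methoxyphenyl on a carbon with a double bond to nitrogen. Within the data shown here, the only measured step that bears on this is the one to compound 3, a 2.6-fold higher number from compound 2 to compound 3 (0.42 log units; beyond the scatter), a modest rise beyond the scatter. A rise of comparable size is expected from compound 2 to compound 4, a 1.9-fold higher number from compound 2 to compound 4 (0.27 log units; within the scatter). The estimate for compound 4 in this assay is 70000 nM, within 25000 nM to 160000 nM.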

Compound 4, concentration for total growth inhibition: 61000 nM
For compound 4 the middle estimate is 1.1-fold (0.06 log units) above the measured one; measured number inside the range.
By their numbers in this assay, from the lowest: compounds 2, 4 and 3 (each within the scatter of the next, the first and the last beyond it). At a limit, above all of these: compound 1.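

In this assay, 3-chlorophenyl in place of 4-methoxyphenyl gives a 1.6-fold higher number from compound 2 to compound 4 (0.21 log units; within the scatter) and so, unlike the change to compound 3, stays inside the scatter. The two chlorophenyl groups cannot be told apart either, with a 1.6-fold lower number from compound 3 to compound 4 (0.21 log units; within the scatter) showing that moving the chlorine leaves no clear difference here. Nothing measured here offers a reason for these small steps.

From the compounds shown here alone, whether 4-chlorophenyl, or a phenyl carrying an amine or a carboxylic acid, on this carbon would take the number clearly below that of compound 2 remains open.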